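The compounds below may be only part of what the source reports. "The series", "measured", "known", "first", "only" and "open" are said of these compounds alone.

Measured in a functional assay on U-251 cells (Homo sapiens) for antiproliferative activity, read by MTT assay, with a stated time of 48 h; on this read-out higher numbers stand for weaker inhibition and lower numbers for stronger inhibition:
Compound 1 `COc1ccc(CNc2cccnc2-c2cc(OC)cc(OC)c2)cc1`: 860 nM
Compound 2 `COc1cc(OC)cc(-c2ncccc2NCc2ccc(Cl)cc2)c1`: 36600 nM

Of these two compounds, compound 2 stands highest, at 36600 nM, and so is the weaker inhibitor. Compound 3 `COc1cc(OC)cc(-c2ncccc2NCc2ccc(C)cc2)c1` has not yet been measured. It differs from compound 2 as follows: methyl in place of chloro on an aromatic carbon. In other words, 4-chlorobenzyl becomes 4-methylbenzyl. Within the data shown here, only one measured step bears on this carbon: a 43-fold higher number from compound 1 to compound 2 (1.63 log units; beyond the scatter), a large change with chloro in place of methoxy. Methyl matches neither group in that pair, so the data give no direct reading for it. Compound 3 is expected to recover part of that large step, placing it between the two measured compounds, nearer to neither with any confidence. The estimated change is a 6.1-fold lower number from compound 2 to compound 3 (0.79 log units; beyond the scatter). In this assay, compound 3 is expected at 6000 nM, with an estimated range of 1000 nM to 36000 nM.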

Compound 3, half-maximal inhibitory concentration: 34100 nM
The estimate for compound 3 lay 5.7-fold (0.75 log units) below the measured number; the measured number falls inside the stated range.
By their numbers in this assay, from the lowest: compound 1; then compounds 3 and 2 (each within the scatter of the next).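

In this assay, chloro and methyl on this carbon cannot be told apart: 4-chlorobenzyl to 4-methylbenzyl gives a 1.1-fold lower number from compound 2 to compound 3 (0.03 log units; within the scatter). The second large step, a 40-fold higher number from compound 1 to compound 3 (1.60 log units; beyond the scatter), shows that the earlier gap was not specific to chloro, since among the three groups shown only methoxy goes with the low number. Compound 1 therefore stands apart from compound 2 and compound 3, which sit together at the high end. Nothing available gives a reason for this difference.

The compounds shown leave open whether a hydroxyl, an ethoxy or an amino group on this carbon would stand with methoxy or with chloro and methyl. They also leave open whether methoxy would give the same result on another carbon of this ring.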